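Amide side-chain changes on the shared core: compound 4

A few compounds are considered here, and "the series" means these few. Any claim that something is new, unique, unknown or untested is made for them only; others in the source may bear on it.

Measured so far in a functional assay on MCF7 cells (Homo sapiens) for cytotoxicity, read by MTT assay, with a stated time of 24 h, tested at 1.6 ug/mL; on this read-out higher numbers stand for a stronger effect at the one concentration tested and lower numbers for a weaker effect:
compound 1 `Cn1c(-c2ccc(NC(=O)CSc3nc4cc(Cl)ccc4o3)cc2)nc(-c2ccccc2)c1-c1ccccc1` gives 2.5%
compound 2 `Cn1cnnc1SCC(=O)Nc1ccc(-c2nc(-c3ccccc3)c(-c3ccccc3)n2C)cc1` gives 42.8%
compound 3 `Cc1nnc(SCC(=O)Nc2ccc(-c3nc(-c4ccccc4)c(-c4ccccc4)n3C)cc2)s1` gives 37.5%

Compound 3 stands second highest of the three. Its nearest neighbour is compound 2, and the step of a number 5.3 percentage points lower from compound 2 to compound 3 (within the scatter) lies within the scatter, so the two cannot be ordered. Its furthest neighbour is compound 1, and the step of a number 35 percentage points higher from compound 1 to compound 3 (beyond the scatter) is large.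

Compound 4 `CN1CCN(CC(=O)Nc2ccc(-c3nc(-c4ccccc4)c(-c4ccccc4)n3C)cc2)CC1` is not yet measured. It differs from compound 3 in one place: 4-methylpiperazin-1-yl in place of (5-methyl-1,3,4-thiadiazol-2-yl)sulfanyl on a saturated chain carbon bound to a carbonyl carbon. The entering group sits on a saturated chain carbon bound to a carbonyl carbon.

Among the compounds with values here, no measured step bears directly on this change. All three steps, a number 40.3 percentage points higher from compound 1 to compound 2 (beyond the scatter), a number 35 percentage points higher from compound 1 to compound 3 (beyond the scatter) and a number 5.3 percentage points lower from compound 2 to compound 3 (within the scatter), swap the ring on the sulfur and keep the sulfur link; none removes it. Within the data shown here, they show only that a change at this end of the amide chain can move this assay a great deal or hardly at all. The direction for compound 4 is therefore open, and the expected step of a number 7.5 percentage points lower from compound 3 to compound 4 (within the scatter) is set near zero with a wide range.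

For compound 4 the estimate in this assay is 30%, between 5% and 60%.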

Compound 4, a percentage reported as activity, at one concentration (the size of the read-out at that concentration, not a potency): 2.9%
Compound 4: middle estimate off by 27.1 percentage points, on the high side, and the stated range ends above it.
By their numbers in this assay, from the lowest: compounds 1 and 4 (each within the scatter of the next); then compounds 3 and 2 (each within the scatter of the next).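

In this assay, 4-methylpiperazin-1-yl on the saturated chain carbon bound to a carbonyl carbon is the first change shown that removes the sulfur link, and it gives large drops from both sulfur-linked five-membered rings: a number 34.6 percentage points lower from compound 3 to compound 4 (beyond the scatter) and a number 39.9 percentage points lower from compound 2 to compound 4 (beyond the scatter). The group leaving in the first of these steps and the group entering both hold 7 heavy atoms, so heavy-atom count alone does not set the reading at this place. The step of a number 0.4 percentage points higher from compound 1 to compound 4 (within the scatter) shows that the low reading occurs both with a sulfur link, in the 5-chloro-1,3-benzoxazol-2-yl compound, and without one, so compound 1 goes against any rule that the sulfur link alone keeps the effect, and no measurement shown here accounts for these differences.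

The compounds shown do not separate the loss of the sulfur from the arrival of the piperazine ring, since both happen in a single change. Going by these compounds, a morpholin-4-yl or dimethylamino group on the same carbon, or a 1,2,4-triazole bound there through a ring nitrogen without sulfur, would bear on that question, and all these readings still come from one concentration, so potency remains open.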